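A few compounds are considered here, and "the series" means these few. Any claim that something is new, unique, unknown or untested is made for them only; others in the source may bear on it.

Compound 1 `NC1CCC(Nc2nc(NCc3ccc(-c4ccccc4)cc3)c3ncn(C4CCCC4)c3n2)CC1`: 530 nM
Compound 2 `NC1CCC(Nc2nc(NCc3ccc(-c4ccco4)nc3)c3ncn(C4CCCC4)c3n2)CC1`: 67 nM
Compound 3 `NC1CCC(Nc2nc(NCc3ccc(-c4ccsc4)nc3)c3ncn(C4CCCC4)c3n2)CC1`: 150 nM

These values come from a functional assay on K562 cells (Homo sapiens) for inhibition, with a stated time of 72 h; on this read-out higher numbers stand for weaker inhibition and lower numbers for stronger inhibition. Compound 1 has the highest number of the three, making it the weakest inhibitor here. Compound 4 `NC1CCC(Nc2nc(NCc3ccc(-c4ccccc4O)cc3)c3ncn(C4CCCC4)c3n2)CC1` differs from compound 1 by a single change: hydroxy in place of hydrogen on an aromatic carbon. This is hydroxy in place of hydrogen on an aromatic carbon, or phenyl to 2-hydroxyphenyl.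

Within the data shown here, no measured step adds a hydroxy, so the evidence is only indirect. Two steps replace the whole 4-phenylphenyl group: a 7.9-fold lower number from compound 1 to compound 2 (0.90 log units; beyond the scatter), and a 3.5-fold lower number from compound 1 to compound 3 (0.55 log units; beyond the scatter). Both lowered the number, so a smaller, uncertain drop is expected in this assay. The expected step is a 1.8-fold lower number from compound 1 to compound 4 (0.25 log units; within the scatter). For compound 4, the estimated value is 300 nM, with an expected range of 110 nM to 800 nM.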

Compound 4, half-maximal inhibitory concentration: 2610 nM
For compound 4 the middle estimate is 8.7-fold (0.94 log units) below the measured one; the whole stated range lies below it.
By their numbers in this assay, from the lowest: compound 2; then compound 3; then compound 1; then compound 4.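

In this assay, phenyl to 2-hydroxyphenyl gives a 4.9-fold higher number from compound 1 to compound 4 (0.69 log units; beyond the scatter), so this single added hydroxy, ortho to a large group, weakens inhibition, whereas both earlier changes from compound 1 strengthened it. One heavy atom on this aromatic ring is therefore enough to shift the result beyond the usual scatter. No measurement here explains this loss.

As far as these compounds go, it remains open whether a methoxy or a fluorine at the same place would behave like the hydroxy. Also open, from the compounds shown here alone, is how a hydroxy would act on the ring carrying furan-2-yl in compound 2.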